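The source may report more compounds than this note shows. Statements on the series, on what has been measured and on what is new or still open speak of the compounds shown alone.

For the measured compounds named here, compound 3 `O=C1C(Nc2ccc(Br)cc2)=CC(=O)c2c1nc1n2[C@H]2OC[C@@H](O)[C@H]2OC1` is the one compound here with a true number: in a functional assay on HeLa cells (Homo sapiens) for inhibition, read by sulforhodamine B assay (on this read-out lower numbers stand for stronger inhibition and higher numbers for weaker inhibition), compound 3 gives 5220 nM. Compound 1 `COc1ccc(NC2=CC(=O)c3c(nc4n3[C@H]3OC[C@@H](O)[C@H]3OC4)C2=O)cc1` sits at a limit of this assay, > 8000 nM. Compound 2 `O=C1C(Nc2ccccc2)=CC(=O)c2c1nc1n2[C@H]2OC[C@@H](O)[C@H]2OC1` also sits at a limit, > 8000 nM. Most of the values are therefore (the limit of > 8000 nM in this assay, at which 2 of the 3 values shown sit).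

Compound 4 `CCCN(CCC)C1=CC(=O)c2c(nc3n2[C@H]2OC[C@@H](O)[C@H]2OC3)C1=O` differs from compound 3 by dipropylamino in place of (4-bromophenyl)amino on a double-bonded ring carbon. The measured steps that come closest are an at least 1.5-fold lower number from compound 1 to compound 3 (0.18 log units; that floor lies within the scatter) and an at least 1.5-fold lower number from compound 2 to compound 3 (0.18 log units; that floor lies within the scatter), both changes of a single group on the aromatic ring rather than removal of the ring itself, and both only floors. The change to compound 4 is expected to raise the number, with a step of a 1.7-fold higher number from compound 3 to compound 4 (0.24 log units; within the scatter) to compound 4. Compound 4 is thus estimated at 9000 nM, within a range from 3000 nM to 30000 nM.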

Compound 4, half-maximal inhibitory concentration: > 16000 nM
Compound 4 gave a limit, no number (the forecaster's own chance of this, stated with the estimate: 55%); middle value at least 1.7-fold (0.24 log units) from the limit.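

For the compounds shown here, putting dipropylamino in place of (4-bromophenyl)amino on this double-bonded ring carbon gives an at least 3.0-fold higher number from compound 3 to compound 4 (0.48 log units; beyond the scatter), the first step in this set that is clearly beyond the scatter. This single change removes both the aromatic ring and the hydrogen-bond donor of the group that leaves, so the two cannot be told apart here. The steps from compound 1 and from compound 2 to compound 4 cannot be read, since each joins two limits: the limit of > 16000 nM in this assay, at which 1 of the 4 values shown sits.

Still open, as far as these compounds go, is how propylamino, which has a hydrogen-bond donor but no aromatic ring, would compare with methyl(phenyl)amino, which has the ring but no such donor. Either group could help show which of the two features matters at this position.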